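The compounds below may be only part of what the source reports. "The series", "measured", "known", "first", "only" and "open" are said of these compounds alone.

Working notes on the series. Compound 2 `N#Cc1cccc(COc2ccc(-c3cc(CN4CCN(c5ccc(C(F)(F)F)cc5)CC4)no3)cc2)c1` is the reference point for the next step. In a functional assay on Mahlavu cells (Homo sapiens) for antiproliferative activity, read by sulforhodamine B assay, with a stated time of 72 h (a lower number here means a stronger inhibitor, a higher number a weaker inhibitor), compound 2 gives 2700 nM. Compound 1 `COc1ccccc1COc1ccc(-c2cc(CN3CCN(Cc4ccc(C(F)(F)F)cc4)CC3)no2)cc1` differs from compound 2 in several places at once; in this assay compound 1 gives 3900 nM. The two numbers lie within the scatter of each other, so nothing separates them. Among the measured compounds shown here, no step between measured compounds that differ in a single place is available, so the change to compound 3 has no direct precedent here.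

Compound 3 `N#Cc1cccc(COc2ccc(-c3cc(CN4CCN(CC5CCCO5)CC4)no3)cc2)c1` carries the change ((oxolan-2-yl)methyl in place of 4-(trifluoromethyl)phenyl on an amine nitrogen in a ring). The small set gives no footing for a confident direction; the expectation is a step of modest size, most likely toward a higher number, not clearly beyond the scatter. The estimate for compound 3 in this assay is 5000 nM, with a range from 1500 nM to 18000 nM. The step this implies, a 1.9-fold higher number from compound 2 to compound 3 (0.27 log units; within the scatter), is an expectation only.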

Compound 3, half-maximal inhibitory concentration: 4800 nM
Estimate against measurement, compound 3: 1.0-fold (0.02 log units) above; the range from low to high includes it.
By their numbers in this assay, from the lowest: compounds 2, 1 and 3 (each within the scatter of the next).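

Among the compounds shown here, this is the first single-place step. In this assay, (oxolan-2-yl)methyl in place of 4-(trifluoromethyl)phenyl on the amine nitrogen of the six-membered ring with 2 nitrogen gives a 1.8-fold higher number from compound 2 to compound 3 (0.25 log units; within the scatter), so the two groups are not separated at this position in this pair, although one is a six-membered aromatic ring of carbon only and the other a five-membered non-aromatic ring with 1 hetero atom and 1 hydrogen-bond acceptor. No measurement shown explains this result.

On these data alone, whether an amine, a carboxylic acid or a longer chain on that ring nitrogen would give a step beyond the scatter remains open. As far as these compounds go, it is also open whether the same exchange reads alike when the nitrile of compound 2 is replaced by a methoxy group.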